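A few compounds are considered here, and "the series" means these few. Any claim that something is new, unique, unknown or untested is made for them only; others in the source may bear on it.

The account begins with compound 3, the compound that carries `CC(C)N(Cc1cccc(OCCCCCC(=O)O)c1)C(=O)c1ccc(-c2ccc3c(c2)OCCO3)cc1`. In an ADME assay on BJ cells (Homo sapiens) for cytotoxicity, read by CellTiter-Glo and resazurin assay, with a stated time of 72 h (on this read-out higher numbers stand for an effect only at larger amounts of compound and lower numbers for an effect already at smaller amounts), compound 3 gives > 21900 nM, which is a limit of the assay and not a number. Its two neighbours stand no differently. Compound 1, `CC(C)N(Cc1cccc(OCCCCCC(=O)O)c1)C(=O)c1ccc(-c2ccoc2)cc1`, gives > 26000 nM in this assay, again a limit. Compound 2, `CC(C)N(Cc1cccc(OCCCCCC(=O)O)c1)C(=O)c1ccc(-c2ccco2)cc1`, gives > 26000 nM in this assay, likewise a limit. Two lines of support sum up this picture: the limit of > 21900 nM in this assay, at which 1 of the 3 values shown sits, and (the limit of > 26000 nM in this assay, at which 2 of the 3 values shown sit). Because all three values are limits, the steps among them cannot be read: a step that the two limits leave unreadable from compound 1 to compound 3, a step that the two limits leave unreadable from compound 2 to compound 3 and a step that the two limits leave unreadable from compound 1 to compound 2 all remain of unreadable size, and none of them shows an effect that a number could be attached to.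

Compound 4, `CC(C)N(Cc1cccc(OCCCCCC(=O)O)c1)C(=O)c1ccc(-c2ccc3cc[nH]c3c2)cc1`, is the next step from compound 3. The change is 1H-indol-6-yl in place of 2,3-dihydro-1,4-benzodioxin-6-yl on an aromatic carbon. Within the data shown here, no measured step bears on this change with a readable size; every step among compounds 1, 2 and 3 sits at a limit, so the only expectation the data allow is that the limit continues. In this assay the expected step that the limit leaves unreadable from compound 3 to compound 4 is therefore none beyond the scatter. Compound 4 is thus estimated to give 26000 nM in this assay, with a range from 10000 nM to 60000 nM, most likely as a limit once more.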

Compound 4, half-maximal effective concentration: > 26000 nM
Compound 4 was reported as a limit; the forecaster's own chance of this, stated with the estimate: 80%; the middle value lies on the limit itself.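

In this assay compound 4 gives > 26000 nM, which is a limit of the assay and not a number. Its steps from compound 1, compound 2 and compound 3 cannot be read. The compounds shown leave open at what amount any of the four would have an effect in this assay, and whether their differing groups change that amount at all.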